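Changing the Halogenated Phenyl Group in an EP1 Antagonist Series

A few compounds are considered here, and "the series" means these few. Any claim that something is new, unique, unknown or untested is made for them only; others in the source may bear on it.

In a functional assay on CHO-K1 cells for antagonist activity at prostaglandin E2 receptor EP1 subtype (Homo sapiens), read by FLIPR (a lower number here means a stronger inhibitor, a higher number a weaker inhibitor), compound 1 `Cc1cc(C(=O)O)nn1Cc1cc(Br)ccc1OCc1ccc(Cl)cc1Cl` gives 0.49 nM, compound 2 `Cc1cc(C(=O)O)nn1Cc1cc(Br)ccc1OCc1ccc(Cl)cc1` gives 8.71 nM, and compound 3 `Cc1cc(C(=O)O)nn1Cc1cc(Br)ccc1OCc1c(F)cccc1F` gives 105 nM, the highest of the three numbers and thus the weakest inhibitor here. The measured steps run a 210-fold higher number from compound 1 to compound 3 (2.33 log units; beyond the scatter) and a 12-fold higher number from compound 2 to compound 3 (1.08 log units; beyond the scatter). Compound 4 `Cc1cc(C(=O)O)nn1Cc1cc(Br)ccc1OCc1cc(Cl)cc(Cl)c1` differs from compound 3 by 3,5-dichlorophenyl in place of 2,6-difluorophenyl on a saturated chain carbon bound to an oxygen on an aromatic ring. For the measured compounds named here, no measured pair shows this exact swap, but both steps above show chlorophenyl groups on the saturated chain carbon bound to an oxygen on an aromatic ring giving far lower numbers than 2,6-difluorophenyl, so a large drop in this assay is expected. Compound 4 is therefore estimated at 10 nM, with a range of 2 nM to 50 nM, an expected step of an 11-fold lower number from compound 3 to compound 4 (1.02 log units; beyond the scatter).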

Compound 4, inhibition constant: 1120 nM
Compound 4: the middle estimate sits 110-fold (2.05 log units) below what was measured; measured number above the stated range.
By their numbers in this assay, from the lowest: compound 1; then compound 2; then compound 3; then compound 4.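

Chlorine on the phenyl group does not by itself give a strong inhibitor: with the two chlorines of 2,4-dichlorophenyl placed as in 3,5-dichlorophenyl, this assay shows a 2300-fold higher number from compound 1 to compound 4 (3.36 log units; beyond the scatter). The 3,5-dichlorophenyl group also falls behind 4-chlorophenyl, with a 130-fold higher number from compound 2 to compound 4 (2.11 log units; beyond the scatter), and even behind 2,6-difluorophenyl, with an 11-fold higher number from compound 3 to compound 4 (1.03 log units; beyond the scatter), making compound 4 the weakest of the four. Nothing measured here explains why the placement of the chlorines matters so much.

The compounds shown leave open how a methoxyphenyl or trifluoromethylphenyl group would compare at this place.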